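The compounds below may be only part of what the source reports. "The series", "measured", "known", "first", "only" and "open" are said of these compounds alone.

In a functional assay, with a stated time of 10 min (a higher number here means a weaker inhibitor, a lower number a stronger inhibitor), compound 1 `CCCCCCCCCCOc1cc(OC)c(Br)cc1C(C)=O` gives 29700000 nM, and compound 2 `CCCCCCCCCCCCOc1cc(OC)c(Br)cc1C(C)=O` gives 23100000 nM. The step between them, a 1.3-fold lower number from compound 1 to compound 2 (0.11 log units; within the scatter), comes from ethyl in place of hydrogen on a saturated chain carbon, ten or more bonds along the chain from an oxygen on an aromatic ring. Compound 3 `CCCCCCOc1cc(OC)ccc1C(C)=O` gives 84400000 nM, the highest of the three numbers, its gap to compound 1 and to compound 2 each lying beyond the scatter. How the core of compound 3 differs from the core of compound 1 is not broken down here. Compound 4 `CCCCCCCCOc1cc(OC)ccc1C(C)=O` has not yet been measured in this assay; it differs from compound 3 by ethyl in place of hydrogen on a saturated chain carbon, six bonds along the chain from an oxygen on an aromatic ring. Among the measured compounds shown here, this is the same kind of change as the one from compound 1 to compound 2, but not the same: the place along the chain from the ring oxygen differs between the two. Because a 1.3-fold lower number from compound 1 to compound 2 (0.11 log units; within the scatter) lay within the scatter, only a small step is expected, and the lower numbers of compound 1 and compound 2 beside compound 3 point the same way. The expected step is a 1.5-fold lower number from compound 3 to compound 4 (0.19 log units; within the scatter). Compound 4 is therefore estimated at 55000000 nM, between 25000000 nM and 120000000 nM.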

Compound 4, half-maximal inhibitory concentration: 69400000 nM
The estimate for compound 4 lay 1.3-fold (0.10 log units) below the measured number; measured number inside the range.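

In this assay the new step stays within the scatter (a 1.2-fold lower number from compound 3 to compound 4 (0.08 log units; within the scatter)). Set beside the earlier step, ethyl in place of hydrogen shows no difference between the two cores: the same change on two cores in this assay, a 1.3-fold lower number (0.11 log units; within the scatter) from compound 1 to compound 2 and a 1.2-fold lower number (0.08 log units; within the scatter) from compound 3 to compound 4, 1.1-fold (0.02 log units) apart, within the scatter of two such steps. This shows that the change carries over between these two cores at these two places along the chain, but both steps are small, so it does not show how the change would behave on other cores or at other chain lengths.

The compounds shown leave open whether a chain ending in an amine or a carboxylic acid would give a step beyond the scatter. They also leave open whether the two cores would still agree with a much longer chain.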